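Sulfonyl aryl exchange on a piperidinylpiperidine sulfonamide core

The compounds below may be only part of what the source reports. "The series", "measured", "known", "first", "only" and "open" are said of these compounds alone.

Compound 1 `Cc1noc(C)c1S(=O)(=O)N1CCC(N2CCC(C)CC2)CC1` carries a 3,5-dimethyl-1,2-oxazol-4-yl on the sulfonyl sulfur. In a functional assay on DLD-1 cells (Homo sapiens) for antiproliferative activity, read by CellTiter-Glo, with a stated time of 72 h (a lower number here means a stronger inhibitor, a higher number a weaker inhibitor), compound 1 gives > 5000 nM, which is a limit of the assay and not a number. Its position on the numbers shown is therefore only this: the limit of > 5000 nM in this assay, at which 1 of the 2 values shown sits. Compound 2 `CC(=O)Nc1ccc(S(=O)(=O)N2CCC(N3CCC(C)CC3)CC2)c2ccccc12`, which differs in the group on the sulfonyl sulfur, gives 1100 nM in this assay, so a measurable value is reachable on the shared core. Compound 3 `CC1CCN(C2CCN(S(=O)(=O)c3cc(Cl)cc(Cl)c3)CC2)CC1` has not been measured in this assay. It differs from compound 1 in one place: 3,5-dichlorophenyl in place of 3,5-dimethyl-1,2-oxazol-4-yl on a sulfonyl sulfur. For the measured compounds named here, no measured pair isolates this exchange, so its size is open. The step of an at least 1.6-fold lower number from compound 1 to compound 3 (0.22 log units; that floor lies within the scatter) is expected to run toward stronger inhibition, beyond the usual scatter, given that compound 2 reaches 1100 nM. Compound 3 is estimated at 3000 nM, with a range from 800 nM to 10000 nM.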

Compound 3, half-maximal inhibitory concentration: 3400 nM
For compound 3 the middle estimate is 1.1-fold (0.05 log units) below the measured one, within the range that was stated.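

In this assay, a 3,5-dichlorophenyl on the sulfonyl sulfur yields a measured number rather than a limit, with compound 3 at 3400 nM. The exchange reads as an at least 1.4-fold lower number from compound 1 to compound 3 (0.16 log units; that floor lies within the scatter), so the compounds shown do not establish a change beyond the usual scatter. The true size of the step remains unknown because compound 1 stands at a limit of the assay: the limit of > 5000 nM in this assay, at which 1 of the 3 values shown sits.

The compounds shown do not separate the contribution of the two chlorines from that of the six-membered aromatic ring of carbon only. Also open, as far as these compounds go, is how this position on the shared core would respond to an amine or a carboxylic acid on that ring in place of the chlorines.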